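A pyrrole in place of the thiophene on compound 1

The source may hold more compounds than are shown below. What is called first, only, known or untested is meant among the compounds shown, and "the series" means these compounds.

Measured in an assay on HEK293 cells for agonist activity at transient receptor potential cation channel subfamily M member 8 (Homo sapiens), read by fluorescence and calcium flux, with a stated time of 15 min; on this read-out lower numbers stand for an effect already at smaller amounts and higher numbers for an effect only at larger amounts of compound:
Compound 1 `CCN(Cc1cccs1)C(=O)COc1ccc(C)cc1` gives 8 nM.
Compound 2 `CCN(Cc1cccs1)C(=O)COc1ccccc1` gives 1400 nM.
Compound 3 `Cc1ccc(OCC(=O)N(Cc2cccs2)c2ccccn2)cc1` gives 200 nM.

Compound 1 stands lowest of the three, with compound 3 nearest and compound 2 furthest. Compound 4 `CCN(Cc1cccn1C)C(=O)COc1ccc(C)cc1` differs from it by 1-methyl-1H-pyrrol-2-yl in place of thiophen-2-yl on a saturated chain carbon bound to an amide-type nitrogen. Neither measured step touches this arm: the step of a 180-fold higher number from compound 1 to compound 2 (2.24 log units; beyond the scatter) concerns the methyl on the aromatic carbon, and a 25-fold higher number from compound 1 to compound 3 (1.40 log units; beyond the scatter) the group on the amide-type nitrogen. Both are large, showing that single changes around the shared core of compound 1 can move this assay a long way, yet they give no direction for the present swap. A moderate rise in the number is therefore expected, a 3.8-fold higher number from compound 1 to compound 4 (0.57 log units; beyond the scatter), with wide uncertainty. Compound 4 is estimated at 30 nM, between 8 nM and 150 nM.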

Compound 4, half-maximal effective concentration: 21300 nM
For compound 4 the middle estimate is 710-fold (2.85 log units) below the measured one, outside the stated range (above it).
By their numbers in this assay, from the lowest: compound 1; then compound 3; then compound 2; then compound 4.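

In this assay, the (thiophen-2-yl)methyl arm, which neither earlier step touched, proves far from neutral: the change to (1-methyl-1H-pyrrol-2-yl)methyl gives a 2700-fold higher number from compound 1 to compound 4 (3.43 log units; beyond the scatter), and this is beyond the scatter. Both arms carry one five-membered aromatic ring with 1 hetero atom and the same counts of hydrogen-bond donors and acceptors, so those shared features do not preserve the low number of compound 1. Nothing shown explains why this swap has so large an effect.

The compounds shown leave open whether the rise follows from the ring nitrogen in place of sulfur or from the methyl on that nitrogen. They also leave open how a 1H-pyrrol-2-yl, a furan-2-yl or a phenyl group would fare on this carbon.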